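Removing a Trifluoromethyl Group: Expected Effect on Solubility

The source may report more compounds than this note shows. Statements on the series, on what has been measured and on what is new or still open speak of the compounds shown alone.

Of the compounds shown here, three sharing one core have been measured in a physicochemical assay for solubility, in phosphate buffer, measured as kinetic solubility, with a stated time of 1 h, at pH 7.4; a higher number here means a more soluble compound, a lower number a less soluble compound. Compound 1 `COc1ccc2nc(C)cc(OCC(=O)Nc3ccccc3)c2c1` gives 63000 nM, compound 2 `COc1ccc2nc(C)cc(OCC(=O)Nc3cc(C)ccc3OC)c2c1` gives 9500 nM, and compound 3 `COc1ccc2nc(C)cc(OCC(=O)Nc3ccc(Cl)c(C(F)(F)F)c3)c2c1` gives 17000 nM. Compound 3 stands second highest of the three: its gap to compound 2 is within the scatter, while compound 1 lies beyond the scatter above it. Within the data shown here, the only single-place step is a 6.6-fold lower number from compound 1 to compound 2 (0.82 log units; beyond the scatter). Compound 4 `COc1ccc2nc(C)cc(OCC(=O)Nc3ccc(Cl)cc3)c2c1` differs from compound 3 by hydrogen in place of trifluoromethyl on an aromatic carbon. Among the measured compounds shown here, no measured step matches this change directly; adding groups to the phenyl lowered the number from compound 1 to compound 2, and compound 1, bearing neither group, lies highest. Compound 4 is expected to show a 1.9-fold higher number from compound 3 to compound 4 (0.27 log units; within the scatter) in this assay, estimated at 32000 nM with a range of 13000 nM to 75000 nM.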

Compound 4, solubility: 9000 nM
The estimate for compound 4 lay 3.6-fold (0.55 log units) above the measured number; the measured number lies below the stated range.
By their numbers in this assay, from the lowest: compounds 4, 2 and 3 (each within the scatter of the next); then compound 1.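

In this assay, hydrogen in place of trifluoromethyl at this position, ortho to a chloro group, gives a 1.9-fold lower number from compound 3 to compound 4 (0.28 log units; within the scatter) and so does not separate the two compounds. The chloro group is now seen alone, and chloro in place of hydrogen on an aromatic carbon gives a 7.0-fold lower number from compound 1 to compound 4 (0.85 log units; beyond the scatter) on this read-out. The exchange of the whole aryl group gives a 1.1-fold lower number from compound 2 to compound 4 (0.02 log units; within the scatter) as well.

On these data alone, whether a carboxylic acid or an amine at this position would move the number beyond the scatter remains open. Nothing shown here bears on the reason for these steps.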